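A few compounds are considered here, and "the series" means these few. Any claim that something is new, unique, unknown or untested is made for them only; others in the source may bear on it.

Compounds measured so far:
- Compound 1 `COc1ccc2c(c1)OC(c1cc(OC)c(OC)c(OC)c1)C(CO)=C2`: in a functional assay for inhibition of nuclear factor NF-kappa-B complex (Homo sapiens) (on this read-out lower numbers stand for stronger inhibition and higher numbers for weaker inhibition), compound 1 gives > 50000 nM, which is a limit of the assay and not a number.
- Compound 2 `COc1ccc2c(c1)OC(c1cc(OC)c(OC)c(OC)c1)C(C(=O)NC(C)(C)C)=C2`: in this assay compound 2 gives 28400 nM.

Going by the values given here, compound 2 therefore carries the only number; the other value shown is the limit of > 50000 nM in this assay, at which 1 of the 2 values shown sits. Among the compounds with values here, the one step between measured compounds is an at least 1.7-fold lower number from compound 1 to compound 2 (0.24 log units; that floor lies within the scatter), a change of hydroxymethyl to (tert-butyl)carbamoyl on a double-bonded ring carbon; its floor lies within the scatter, so it shows no firm movement.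

Compound 3 `COc1ccc2c(c1)OC(c1cc(OC)c(OC)c(OC)c1)C(C(=O)OC(C)C)=C2` has not been measured. It differs from compound 2 by isopropoxy in place of (tert-butyl)amino on a carbonyl carbon. The change keeps the carbonyl on the double-bonded ring carbon and exchanges only the group beyond it, so the step from compound 1 to compound 2 bears on it only loosely, and that step itself was not resolved beyond the scatter. Within the data shown here, no measured step therefore points to a direction in this assay. The expectation for compound 3 is a step of a 1.1-fold higher number from compound 2 to compound 3 (0.02 log units; within the scatter), that is, no movement beyond the scatter. Compound 3 is estimated at 30000 nM, within 10000 nM to 100000 nM, with a real chance that only a limit is reported.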

Compound 3, half-maximal inhibitory concentration: 11800 nM
Estimate against measurement, compound 3: 2.5-fold (0.41 log units) above; measured number inside the range.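

In this assay, the series shows a 2.4-fold lower number from compound 2 to compound 3 (0.38 log units; beyond the scatter). Going by these compounds alone, this is the first movement beyond the scatter among compounds that keep the carbonyl on the double-bonded ring carbon, so the group beyond that carbonyl does affect the read-out. Against hydroxymethyl, the series now shows an at least 4.2-fold lower number from compound 1 to compound 3 (0.62 log units; beyond the scatter), a separation that (tert-butyl)carbamoyl did not establish, although the size of this step remains a floor and the value of compound 1 is a limit and not a number: the limit of > 50000 nM in this assay, at which 1 of the 3 values shown sits.

The change from (tert-butyl)amino to isopropoxy alters both the atom attached to the carbonyl carbon and the branched alkyl group, and the compounds shown cannot separate these two parts; tert-butoxy or isopropylamino on the same carbonyl carbon would divide the change. On these data alone, it also remains open how a carboxylic acid or a longer straight-chain ester at this position would read out. As far as these compounds go, whether any group here can bring the number far lower is likewise open; the reference point is compound 3 with 11800 nM.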